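A few compounds are considered here, and "the series" means these few. Any claim that something is new, unique, unknown or untested is made for them only; others in the source may bear on it.

Measured compounds in a functional assay on THP-1 cells (Homo sapiens) for inhibition, read by sulforhodamine B assay, with a stated time of 48 h, tested at 50 uM; on this read-out lower numbers stand for less inhibition of growth and higher numbers for more inhibition of growth at the one concentration tested:
- compound 1, `COc1ccccc1/C=C/C(=O)/C=C/c1ccc(OCc2cn(CCCOc3cc(=O)oc4ccccc34)nn2)c(OC)c1`, gives 50%
- compound 2, `COc1ccc(/C=C/C(=O)/C=C/c2ccc(OCc3cn(CCCCCOc4cc(=O)oc5ccccc45)nn3)c(OC)c2)cc1`, gives 39%

Compound 2 stands lowest of the two numbers in this assay. Its nearest neighbour is compound 1, whose number lies higher by a gap beyond the usual scatter, so the two are distinguishable on this read-out. For the measured compounds named here, no pair of measured compounds differs in a single place, so no measured step is available to lean on, and the two structures differ in more than one respect; only what their two values show can be stated.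

The next compound, compound 3, `COc1cc(/C=C/C(=O)/C=C/c2cc(OC)c(OC)c(OC)c2)ccc1OCc1cn(CCCCCOc2cc(=O)oc3ccccc23)nn1`, is to be measured in this assay. It is derived from compound 2 by one change: 3,4,5-trimethoxyphenyl in place of 4-methoxyphenyl on a double-bonded chain carbon bound to a double-bonded chain carbon. Nothing measured in the series reports the effect of this particular exchange, so the size and direction of the step from compound 2 to compound 3 is open. The working expectation is a moderate rise in inhibition of growth, of a size close to the scatter edge, as a number 9 percentage points higher from compound 2 to compound 3 (within the scatter). Compound 3 is accordingly estimated at 48%, within a range of 30% to 66%.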

Compound 3, percent growth inhibition at one concentration: 55%
Estimate against measurement, compound 3: 7 percentage points below; measured number inside the range.
By their numbers in this assay, from the lowest: compound 2; then compounds 1 and 3 (each within the scatter of the next).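

In this assay, for the compounds shown here, the exchange of 4-methoxyphenyl for 3,4,5-trimethoxyphenyl on a double-bonded chain carbon bound to a double-bonded chain carbon gives a number 16 percentage points higher from compound 2 to compound 3 (beyond the scatter), the only step that can be read at a single place. The aryl group at this position therefore bears on growth inhibition, which the two earlier compounds could not show because they differ in more than one respect. The entering group brings 12 heavy atoms in place of 8 and 3 hydrogen-bond acceptors in place of 1, and no measured evidence here links either count, or anything else about the exchange, to the rise.

The compounds shown leave open whether one or two methoxy groups on this phenyl ring would give part of the step, and whether the rise would persist with a dimethylamino group or a carboxylic acid on the ring. Also open, going by these compounds, is whether 3,4,5-trimethoxyphenyl would give a step of similar size and direction on a compound with a longer chain on the triazole nitrogen.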